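The source may hold more compounds than are shown below. What is called first, only, known or untested is meant among the compounds shown, and "the series" means these compounds.

Of the compounds shown here, two built on a shared core have been measured in an assay on tissue (HeLa cells) for inhibition of Indoleamine 2,3-dioxygenase 1 (Homo sapiens), read by spectrophotometry; on this read-out higher numbers stand for weaker inhibition and lower numbers for stronger inhibition. Compound 1 `O/N=C(/Nc1cccc(COc2ccccc2)c1)c1ccc2occc2c1` reaches only > 30000 nM, which is a limit of the assay and not a number. Compound 2 `O/N=C(/NCc1ccccc1)c1ccc2occc2c1` gives 28200 nM in this assay, and this is the only actual number among the results shown. The other result sits at a limit: the limit of > 30000 nM in this assay, at which 1 of the 2 values shown sits. Compound 3 `O/N=C(/NCc1cccs1)c1ccc2occc2c1` has not yet been measured. It differs from compound 2 in one place: thiophen-2-yl in place of phenyl on a saturated chain carbon bound to an amine nitrogen. Among the measured compounds shown here, no step between two measured compounds is available to show how large a change such a swap brings. In this assay the step from compound 2 to compound 3 is expected to be small, in either direction or none beyond the usual scatter, estimated as a 1.1-fold lower number from compound 2 to compound 3 (0.05 log units; within the scatter). Compound 3 is therefore estimated at 25000 nM, within an expected range from 10000 nM to 60000 nM.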

Compound 3, half-maximal inhibitory concentration: 16200 nM
Beside the measured number, compound 3's estimate is 1.5-fold (0.19 log units) above it, and the stated range covers the measured number.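

Among the compounds shown here, this is the first step that can be read at this position: in this assay, the swap gives a 1.7-fold lower number from compound 2 to compound 3 (0.24 log units; within the scatter). On a saturated chain carbon bound to an amine nitrogen, thiophen-2-yl can therefore replace phenyl, with one heavy atom fewer and a sulfur in the ring, without a difference that these data can separate from repeat measurement. Compound 1 remains a limit of the assay and not a number: the limit of > 30000 nM in this assay, at which 1 of the 3 values shown sits.

The compounds shown do not tell how a pyridin-2-yl ring, a cyclohexyl ring or a longer chain would behave at this place. As far as these compounds go, whether any group here can move the number beyond the scatter therefore remains open.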